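A few compounds are considered here, and "the series" means these few. Any claim that something is new, unique, unknown or untested is made for them only; others in the source may bear on it.

In a functional assay (blood) for inhibition, with Homo sapiens as the target (a higher number here means a weaker inhibitor, a lower number a stronger inhibitor), three compounds on a shared core differ only in one side group. Compound 1 `CC(O)c1cc(-c2ccccc2)c2ccc(OCc3cccc(C4(O)CCOCC4)c3)cc2c1`, carrying 1-hydroxyethyl, gives 675 nM. Compound 2 `COCc1cc(-c2ccccc2)c2ccc(OCc3cccc(C4(O)CCOCC4)c3)cc2c1`, carrying methoxymethyl, gives 200 nM. That swap is a 3.4-fold lower number from compound 1 to compound 2 (0.53 log units; beyond the scatter).

Compound 3 `COC(C)c1cc(-c2ccccc2)c2ccc(OCc3cccc(C4(O)CCOCC4)c3)cc2c1`, carrying 1-methoxyethyl, gives only a limit, > 1000 nM, and no number. Its steps are therefore floors: an at least 5.0-fold higher number from compound 2 to compound 3 (0.69 log units; beyond the scatter), and an at least 1.4-fold higher number from compound 1 to compound 3 (0.17 log units; that floor lies within the scatter).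

Compound 4 `CC(=O)c1cc(-c2ccccc2)c2ccc(OCc3cccc(C4(O)CCOCC4)c3)cc2c1` has not yet been measured. The change is acetyl in place of 1-methoxyethyl on an aromatic carbon. Within the data shown here, no measured step makes this exact swap, so the guide is the other groups tried at this place. Both gave measured numbers, compound 1 at 675 nM and compound 2 at 200 nM. Acetyl has the same carbon skeleton as the 1-hydroxyethyl of compound 1, so a value near compound 1 seems the likeliest outcome, and a modest step towards a lower number is expected in this assay. Another limit reading remains possible.

The expected change is an at least 1.8-fold lower number from compound 3 to compound 4 (0.25 log units; that floor lies within the scatter). For compound 4 the estimate is 550 nM, with an expected range of 200 nM to 1000 nM.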

Compound 4, half-maximal inhibitory concentration: 90 nM
The estimate for compound 4 lay 6.1-fold (0.79 log units) above the measured number, and the stated range ends above it.
By their numbers in this assay, from the lowest: compound 4; then compound 2; then compound 1. At a limit, above all of these: compound 3.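

In this assay, acetyl gives the lowest number of the side groups tried at this place on the shared core, with a 2.2-fold lower number from compound 2 to compound 4 (0.35 log units; beyond the scatter) and the same direction in every comparison. The carbon skeleton alone does not set the number, as compound 1 and compound 4 share that skeleton and still show a 7.5-fold lower number from compound 1 to compound 4 (0.88 log units; beyond the scatter). Acetyl and 1-methoxyethyl also have the same counts of hydrogen-bond donors and acceptors, so those counts alone do not set the number either, yet the swap gives an at least 11-fold lower number from compound 3 to compound 4 (1.04 log units; beyond the scatter), which is only a floor as compound 3 stands at a limit: the limit of > 1000 nM in this assay, at which 1 of the 4 values shown sits.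

These compounds leave open whether the carbonyl itself is what matters, a question that an ethyl group, with no oxygen, or a longer ketone such as propanoyl could answer at this place. Going by these compounds, the true number of compound 3 also remains unknown, and with it the full size of its step to compound 4.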